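The compounds below may be only part of what the source reports. "The series", "measured", "known", "first", "only" and "open" are said of these compounds alone.

In a functional assay on NCI-H460 cells (Homo sapiens) for cytotoxicity, read by sulforhodamine B assay, with a stated time of 3 days (on this read-out higher numbers stand for weaker inhibition and lower numbers for stronger inhibition), compound 1 `OCc1cn(Cc2ccc(Cl)cc2)c2ccccc12` gives 16 nM. Compound 3 `OCc1cn(Cc2ccc(Cl)c(Cl)c2)c2ccccc12` gives 31 nM, a change of a 1.9-fold higher number from compound 1 to compound 3 (0.29 log units; within the scatter), so these two stand level. Compound 2 `O=[N+]([O-])c1ccc(Cn2cc(CO)c3ccccc32)cc1` gives 79 nM. Compound 4 `COC(=O)CNCc1cn(Cc2ccc(Cl)cc2)c2ccccc12` carries ((methoxycarbonyl)methyl)amino in place of hydroxy on a saturated chain carbon bound to an aromatic carbon. Among the measured compounds shown here, both measured steps fall on an aromatic carbon, not at this place, so they bear on it only loosely and no measurement yet covers this swap. The best guide is a 4.9-fold higher number from compound 1 to compound 2 (0.69 log units; beyond the scatter), and a move of similar size toward weaker inhibition in this assay is expected. The expected step is a 6.3-fold higher number from compound 1 to compound 4 (0.80 log units; beyond the scatter). Compound 4 is estimated at 100 nM, within a range of 20 nM to 700 nM.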

Compound 4, half-maximal inhibitory concentration: 100 nM
Estimate against measurement, compound 4: no gap at the digits printed; measured number inside the range.
By their numbers in this assay, from the lowest: compounds 1 and 3 (each within the scatter of the next); then compounds 2 and 4 (each within the scatter of the next).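

Among the compounds shown here, this is the first change measured on a saturated chain carbon bound to an aromatic carbon, rather than on an aromatic carbon. In this assay, replacing hydroxy with ((methoxycarbonyl)methyl)amino gives a 6.3-fold higher number from compound 1 to compound 4 (0.80 log units; beyond the scatter), so a group of 6 heavy atoms in place of 1 costs only a modest step here. No measured evidence gives a cause for this step.

The compounds shown leave open whether the amino nitrogen or the methyl ester drives the step, as both enter together. A simple amine or the corresponding carboxylic acid at this place would help separate them.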